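From 4-fluorophenoxy to 2,3,5-trifluorophenoxy in compound 3

The source may report more compounds than this note shows. Statements on the series, on what has been measured and on what is new or still open speak of the compounds shown alone.

In a functional assay with Homo sapiens as the target (on this read-out lower numbers stand for stronger inhibition and higher numbers for weaker inhibition), compound 1 (`CC(C)[C@H](NC(=O)COc1cccc2ccccc12)C(=O)N[C@@H](CC(=O)O)C(=O)COc1ccccc1F`) gives 15700 nM and compound 2 (`CC(C)[C@H](NC(=O)COc1cccc2ccccc12)C(=O)N[C@@H](CC(=O)O)C(=O)COc1ccc(F)cc1`) gives 14300 nM. These two values are all that has been measured so far. The a 1.1-fold lower number from compound 1 to compound 2 (0.04 log units; within the scatter) lies within the scatter, so compound 2 stands level with compound 1 and the pair cannot be ranked.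

Compound 3 (`CC(C)[C@H](NC(=O)COc1cccc2ccccc12)C(=O)N[C@@H](CC(=O)O)C(=O)COc1cc(F)cc(F)c1F`) keeps the shared core and carries 2,3,5-trifluorophenyl in place of 4-fluorophenyl on an oxygen on a saturated carbon.

For the measured compounds named here, only one measured step bears on this change, a swap of 2-fluorophenyl for 4-fluorophenyl at the same place, and its size, a 1.1-fold lower number from compound 1 to compound 2 (0.04 log units; within the scatter), is within the scatter. Going by the values given here, that step moves from one monofluorinated group to another, and no measured compound carries a trifluorophenyl group, so the evidence is thin and the range must stay wide. The expected change is a 1.3-fold lower number from compound 2 to compound 3 (0.11 log units; within the scatter), which means no expected step beyond the scatter in this assay. For compound 3 the estimated value is 11000 nM, with an expected range of 4000 nM to 25000 nM.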

Compound 3, half-maximal inhibitory concentration: 11200 nM
The estimate for compound 3 lay 1.0-fold (0.01 log units) below the measured number, within the range that was stated.
By their numbers in this assay, from the lowest: compounds 3, 2 and 1 (each within the scatter of the next).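

Working notes on the aryloxy position: in this assay the change to 2,3,5-trifluorophenyl gives a 1.3-fold lower number from compound 2 to compound 3 (0.11 log units; within the scatter) and, starting from the other monofluorinated group, a 1.4-fold lower number from compound 1 to compound 3 (0.15 log units; within the scatter) with neither step beyond the scatter. For the compounds shown here, compound 3 therefore stands level with compound 2 and compound 1, so this position on an oxygen on a saturated carbon now shows no separation for a phenyl ring carrying three fluorines rather than one, where the earlier pair compared only two monofluorinated groups. Nothing at hand on these compounds accounts for their level numbers.

The compounds shown leave open whether a phenyl ring with no fluorine, or one carrying an amine or a nitrile, would give a step beyond the scatter in this assay at this same place. Also open, from the compounds shown here alone, is whether a longer chain between the oxygen and the phenyl ring, or a pyridine ring in place of the phenyl ring, would separate from these three compounds, which so far stand level and cannot be ranked.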